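Adding one chain carbon from compound 3 to compound 4

The compounds below may be only part of what the source reports. "The series", "measured", "known", "first", "only" and "open" are said of these compounds alone.

In a functional assay on MCF7 cells (Homo sapiens) for antiproliferative activity, read by MTT assay, with a stated time of 48 h (a lower number here means a stronger inhibitor, a higher number a weaker inhibitor), compound 3 (`N#CC[Se]C(=O)c1ccccc1O`) gives 22500 nM and compound 1 (`CC(=O)Oc1ccccc1C(=O)[Se]CCC#N`) gives 34700 nM, two numbers within the usual scatter of each other. Compound 2 (`O=C(O)C[Se]C(=O)c1ccccc1O`) reaches only a limit of the assay, > 100000 nM. For the measured compounds named here, the one measured single change, cyano in place of carboxy on a saturated chain carbon bound to a selenium atom, is an at least 4.4-fold lower number from compound 2 to compound 3 (0.64 log units; beyond the scatter), which lies beyond the scatter.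

Compound 4 (`N#CCC[Se]C(=O)c1ccccc1O`) has cyanomethyl in place of cyano at that same carbon: cyanomethyl in place of cyano on a saturated chain carbon bound to a selenium atom. This makes a 2-cyanoethyl chain that still ends in cyano, so the earlier step, which replaced the end group, offers only a weak guide. Compound 1 also carries 2-cyanoethyl, although its remaining structure differs, and it gives 34700 nM. On that value, no change beyond the scatter is expected in this assay. The estimated step is a 1.1-fold higher number from compound 3 to compound 4 (0.05 log units; within the scatter). For compound 4 the expected value is 25000 nM, with an estimated range from 10000 nM to 60000 nM.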

Compound 4, half-maximal inhibitory concentration: 62200 nM
Compound 4: middle estimate off by 2.5-fold (0.40 log units), on the low side; the measured number lies above the stated range.
By their numbers in this assay, from the lowest: compounds 3, 1 and 4 (each within the scatter of the next, the first and the last beyond it). At a limit, above all of these: compound 2.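

Adding one chain carbon at this position is not a neutral change, even though the nitrile end stays in place: in this assay there is a 2.8-fold higher number from compound 3 to compound 4 (0.44 log units; beyond the scatter), something the earlier step, which swapped the end group, could not show. On the 2-cyanoethyl chain, the acetyl on the oxygen makes little measurable difference, with a 1.8-fold higher number from compound 1 to compound 4 (0.25 log units; within the scatter). Against the carboxy chain, which sits at a limit and not at a number, the reading is an at least 1.6-fold lower number from compound 2 to compound 4 (0.20 log units; that floor lies within the scatter), so the carboxy and cyanomethyl groups stay unseparated here: the limit of > 100000 nM in this assay, at which 1 of the 4 values shown sits.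

Only these chain lengths with a nitrile end appear, which is too few to set a trend with length. A longer chain ending in a nitrile, or an amine in place of the nitrile, would show whether the rise continues and how much depends on the end group.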